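This account rests on a few compounds, and the source may have more. Where it says the series, first, only, none or still open, it means among the compounds named here.

Compound 2, `COc1ccc2[nH]c3c(c2c1)CCNC31CCN(Cc2ccc(F)c(F)c2)CC1`, gives in an assay on FRT cells for positive allosteric modulation of Cystic fibrosis transmembrane conductance regulator variant N1303K (Homo sapiens), in the presence of a further agent that is not named here (on this read-out lower numbers stand for an effect already at smaller amounts and higher numbers for an effect only at larger amounts of compound), a value of 11000 nM. Within the data shown here, its only neighbour with a number so far is compound 1, `COc1ccc2[nH]c3c(c2c1)CCNC31CCN(Cc2cc(Cl)ccc2[N+](=O)[O-])CC1`, which in this assay gives 7100 nM; the step of a 1.5-fold higher number from compound 1 to compound 2 (0.19 log units; within the scatter) stays within the scatter, so compound 2 stands highest of two numbers without being distinguishable from compound 1 on this read-out.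

Compound 3, `COc1ccc2[nH]c3c(c2c1)CCNC31CCN(Cc2ccco2)CC1`, differs from compound 2 in one place: furan-2-yl in place of 3,4-difluorophenyl on a saturated chain carbon bound to an amine nitrogen in a ring. Among the measured compounds shown here, no measured step exchanges a six-membered carbon-only aromatic ring for a five-membered ring with one hetero atom at this position; the single step known here, a 1.5-fold higher number from compound 1 to compound 2 (0.19 log units; within the scatter), only shows that swapping one substituted phenyl for another left the number within the scatter. On that basis no step beyond the scatter is expected in this assay from compound 2 to compound 3, and the estimated change is a 1.1-fold higher number from compound 2 to compound 3 (0.04 log units; within the scatter). For compound 3 the expected value in this assay is 12000 nM, with a range from 4000 nM to 40000 nM.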

Compound 3, half-maximal effective concentration: 16400 nM
Estimate against measurement, compound 3: 1.4-fold (0.14 log units) below, within the range that was stated.
By their numbers in this assay, from the lowest: compounds 1, 2 and 3 (each within the scatter of the next, the first and the last beyond it).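

In this assay furan-2-yl takes the place of 3,4-difluorophenyl on a saturated chain carbon bound to an amine nitrogen in a ring with a 1.5-fold higher number from compound 2 to compound 3 (0.17 log units; within the scatter), so at this position a five-membered aromatic ring with one hetero atom gives a number that cannot be told apart from that of the six-membered carbon-only ring of compound 2. Set against 5-chloro-2-nitrophenyl, the same group gives a 2.3-fold higher number from compound 1 to compound 3 (0.36 log units; beyond the scatter), the first step at this position beyond the scatter, though a modest one, while compound 2 remains within the scatter of both neighbours. No measurement at hand accounts for either step.

Still open, as far as these compounds go, is whether a basic amine, a carboxylic acid or a longer chain at this position would move the number clearly away from this narrow band. Also open, from the compounds shown here alone, is whether a pyridine ring or a furan carrying a substituent would behave like furan-2-yl.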